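The compounds below may be only part of what the source reports. "The series", "measured", "known", "first", "only" and "open" are said of these compounds alone.

Measured compounds:
Compound 1 `O=C(Nc1nc2ccc(Cl)cc2s1)c1cn(-c2ccccc2)nc1-c1ccc(F)cc1` gives 3320 nM in a functional assay on HT-29 cells (Homo sapiens) for cytotoxicity, read by MTT assay, with a stated time of 72 h; on this read-out lower numbers stand for stronger inhibition and higher numbers for weaker inhibition.
Compound 2 `COc1ccc2nc(NC(=O)c3cn(-c4ccccc4)nc3-c3ccc(F)cc3)sc2c1` gives 33200 nM in this assay.
Compound 3 `Cc1ccc2nc(NC(=O)c3cn(-c4ccccc4)nc3-c3ccc(F)cc3)sc2c1` gives 22900 nM in this assay.

Compound 2 carries the highest number of the three: the step of a 10-fold higher number from compound 1 to compound 2 (1.00 log units; beyond the scatter) lies beyond the scatter, whereas the step of a 1.4-fold lower number from compound 2 to compound 3 (0.16 log units; within the scatter) lies within it, so compound 2 and compound 3 cannot be ordered against each other. Compound 4 `COc1ccc2nc(NC(=O)c3cn(-c4ccccc4)nc3-c3ccc(Cl)cc3)sc2c1` differs from compound 2 by chloro in place of fluoro on an aromatic carbon, the 4-fluorophenyl becoming a 4-chlorophenyl. For the measured compounds named here, none of the measured steps touches this part of the molecule: a 10-fold higher number from compound 1 to compound 2 (1.00 log units; beyond the scatter), a 6.9-fold higher number from compound 1 to compound 3 (0.84 log units; beyond the scatter) and a 1.4-fold lower number from compound 2 to compound 3 (0.16 log units; within the scatter) all exchange the group on a different part of the shared core. They show that the series can respond strongly to such an exchange elsewhere, but they give no direct guide to a fluoro-to-chloro swap at this place. Going by the values given here, with no bearing step available, compound 4 is expected to show a step of a 1.3-fold lower number from compound 2 to compound 4 (0.12 log units; within the scatter) in this assay, not beyond the scatter. Compound 4 is therefore estimated at 25000 nM, with a range from 8000 nM to 80000 nM.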

Compound 4, half-maximal inhibitory concentration: 18600 nM
Estimate against measurement, compound 4: 1.3-fold (0.13 log units) above; the range from low to high includes it.
By their numbers in this assay, from the lowest: compound 1; then compounds 4, 3 and 2 (each within the scatter of the next).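

In this assay, replacing 4-fluorophenyl with 4-chlorophenyl gives a 1.8-fold lower number from compound 2 to compound 4 (0.25 log units; within the scatter) and so cannot be told from the scatter. For the compounds shown here, this is the first measured step at this place, on an aromatic carbon para to a large group, and it shows that this fluoro-to-chloro swap, with compound 2 as the starting point, leaves the number within the scatter, unlike a 10-fold higher number from compound 1 to compound 2 (1.00 log units; beyond the scatter) on another part of the shared core. No accompanying measurement offers an explanation for this result.

The compounds shown leave open whether an amine or a carboxylic acid in place of the halogen at this position would move the number beyond the scatter. They also leave open whether the same fluoro-to-chloro swap would stay within the scatter when made on compound 1, which carries chloro on the shared core.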